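From 3-hydroxypropyl to propyl on a shared core

The compounds below may be only part of what the source reports. "The series", "measured", "known", "first", "only" and "open" are said of these compounds alone.

- compound 1 `Cc1cc(OCC(C)C)cc(C)c1-c1cccc(COc2ccc(OCC(=O)O)c(F)c2)c1`: "not determined" (no result reported)
- compound 2 `CCCCOc1cc(C)c(-c2cccc(COc3ccc(OCC(=O)O)c(F)c3)c2)c(C)c1`: "not determined" (no result reported)
- compound 3 `Cc1cc(OCCCO)cc(C)c1-c1cccc(COc2ccc(OCC(=O)O)c(F)c2)c1`: 2.73

Among the measured compounds shown here, in a physicochemical assay for lipophilicity, using the shake flask method, in phosphate buffer, measured as octanol-water partition, with a stated time of 24 h, at pH 7.4, tested at 100 uM (on this read-out lower numbers stand for lower lipophilicity and higher numbers for higher lipophilicity), compound 3 gives 2.73, and this is the only number available for the series. Compound 1 and compound 2 have no reported result, so compound 3 cannot be ranked against either of them.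

Compound 4 `CCCOc1cc(C)c(-c2cccc(COc3ccc(OCC(=O)O)c(F)c3)c2)c(C)c1` has yet to be measured. It differs from compound 3 by hydrogen in place of hydroxy on a saturated chain carbon, three bonds along the chain from an oxygen on an aromatic ring. This places hydrogen in place of hydroxy on a saturated chain carbon, three bonds along the chain from an oxygen on an aromatic ring, turning 3-hydroxypropyl into propyl.

For the measured compounds named here, no measured pair shows the size of this change, so the expectation has no direct calibration. Starting from compound 3 at 2.73, a clear rise in this assay, well beyond the scatter, is expected. The estimated step is a number 1.17 log units higher from compound 3 to compound 4 (beyond the scatter). For compound 4 the expected value is 3.9, within an estimated range from 3.4 to 4.4.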

Compound 4, distribution coefficient: 3.64
Compound 4: the middle estimate sits 0.26 log units above what was measured; the measured number falls inside the stated range.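

In this assay the series now has its first measured step: hydrogen in place of hydroxy on a saturated chain carbon, three bonds along the chain from an oxygen on an aromatic ring, gives a number 0.91 log units higher from compound 3 to compound 4 (beyond the scatter). This shows that the change from 3-hydroxypropyl to propyl, in which a hydroxy group counted as a hydrogen-bond donor and acceptor leaves and no net charge is involved, registers clearly at this position on the shared core. No supporting measurement accounts for the size of this step, which rests on this one pair.

Steps involving compound 1 or compound 2 cannot be read, so the place of compound 4 among these chains stays open. Also open, as far as these compounds go, is how an amine at the chain end, or a longer chain carrying a terminal hydroxy, would compare on this core.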